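Lengthening the Chain Further: From Decyl to Nonadecyl

A few compounds are considered here, and "the series" means these few. Any claim that something is new, unique, unknown or untested is made for them only; others in the source may bear on it.

Two measured compounds share one core and differ only in the length of a saturated chain attached to it. Compound 1, `CCCCCCCCCCCCCCCCc1c(C)c(N(C)C)nc(C)c1O`, gives 37% in a functional assay on cells (Lymphocyte), read by a luciferase reporter and ATP content, with a stated time of 48 h, tested at 25 uM; on this read-out higher numbers stand for a weaker effect at the one concentration tested and lower numbers for a stronger effect. Compound 2, `CCCCCCCCCCc1c(C)c(N(C)C)nc(C)c1O`, gives 2% in this assay. Compound 2 thus stands at the lowest of the two numbers, the stronger effect, with compound 1 the nearest and only other point. Within the data shown here, the single known step, a number 35 percentage points lower from compound 1 to compound 2 (beyond the scatter), came with hydrogen in place of hexyl on a saturated chain carbon, ten or more bonds along the chain from an aromatic carbon, so shortening the chain brought a large drop.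

Compound 3, `CCCCCCCCCCCCCCCCCCCc1c(C)c(N(C)C)nc(C)c1O`, is not yet measured. It differs from compound 2 by nonyl in place of hydrogen on a saturated chain carbon, ten or more bonds along the chain from an aromatic carbon. This change runs the same way as the known step but in the opposite direction and further, so a rise beyond the scatter is expected in this assay. Compound 3 is therefore estimated to read 45%, within 25% to 70%. The expected step is a number 43 percentage points higher from compound 2 to compound 3 (beyond the scatter), though with one step to go on its size remains uncertain.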

Compound 3, a percentage reported as activity, at one concentration (the size of the read-out at that concentration, not a potency): 86%
Compound 3: the middle estimate sits 41 percentage points below what was measured; the measured number lies above the stated range.
By their numbers in this assay, from the lowest: compound 2; then compound 1; then compound 3.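

Among these compounds, the read-out does not level off at the longer chain: in this assay, nonyl in place of hydrogen brings the largest step seen so far (it gives a number 84 percentage points higher from compound 2 to compound 3 (beyond the scatter)), and the order of the three numbers now follows chain length, with no compound among them going against it. Even the small extension of propyl in place of hydrogen on compound 1 moves the number a long way (it gives a number 49 percentage points higher from compound 1 to compound 3 (beyond the scatter)), further than the removal of hexyl did in the other direction (it gave a number 35 percentage points lower from compound 1 to compound 2 (beyond the scatter)), so equal additions of chain carbons need not bring equal changes along this series. Nothing shown explains why the effect at the one tested concentration weakens as this chain grows.

Among the compounds shown here, with only three chain lengths, the shape of the trend between the decyl chain and the longer ones remains open, and a dodecyl chain would show whether the rise begins soon after decyl or much further out. Also open, from the compounds shown here alone, is whether a chain of similar length carrying a carboxylic acid or an amine would follow the same course.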